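Urea aryl exchange at a compound sitting on the limit

The source may report more compounds than this note shows. Statements on the series, on what has been measured and on what is new or still open speak of the compounds shown alone.

Measured compounds:
Compound 1 `O=C(Nc1cccc(-n2cc(-c3ccncc3)c(-c3ccc(Cl)c(O)c3)n2)c1)Nc1cc(C(F)(F)F)cc(C(F)(F)F)c1`: 14000 nM
Compound 2 `COc1cc(-c2nn(-c3cccc(NC(=O)Nc4cccc(C(F)(F)F)c4)c3)cc2-c2ccncc2)ccc1Cl`: > 50000 nM
Compound 3 `O=C(Nc1cccc(-n2cc(-c3ccncc3)c(-c3ccc(Cl)c(O)c3)n2)c1)Nc1cccc(C(F)(F)F)c1`: > 32500 nM

In a functional assay on T47D cells (Homo sapiens) for inhibition, read by sulforhodamine B assay, with a stated time of 48 h (on this read-out lower numbers stand for stronger inhibition of growth and higher numbers for weaker inhibition of growth), compound 1 gives 14000 nM. Compound 3 gives only a limit, > 32500 nM, and compound 2 gives only a limit as well, > 50000 nM. Compound 2 therefore stands at the top of the numbers shown, with no readable value of its own.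

The unmeasured compound 4 `COc1cc(-c2nn(-c3cccc(NC(=O)Nc4ccc(Cl)c(Cl)c4)c3)cc2-c2ccncc2)ccc1Cl` differs from compound 2 in one place: 3,4-dichlorophenyl in place of 3-(trifluoromethyl)phenyl on an amide-type nitrogen. The measured step of an at least 2.3-fold higher number from compound 1 to compound 3 (0.36 log units; beyond the scatter) concerns the same ring on the amide-type nitrogen and shows that removing trifluoromethyl there weakened inhibition; the step that the two limits leave unreadable from compound 2 to compound 3 is unreadable because of the limit of > 32500 nM in this assay, at which 1 of the 3 values shown sits, and (the limit of > 50000 nM in this assay, at which 1 of the 3 values shown sits). No measured step exchanges the aryl on that nitrogen for a dichlorophenyl, so its size cannot be read from the shown pairs.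

Compound 4 is expected to remain a weak inhibitor, with an estimated step of an at least 1.2-fold lower number from compound 2 to compound 4 (0.09 log units; that floor lies within the scatter) that is most likely unreadable since compound 2 itself only gives a limit. The estimate for compound 4 is 40000 nM, ranging from 12000 nM to 80000 nM.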

Compound 4, concentration for total growth inhibition: > 50000 nM
Compound 4: a limit, no number (the forecaster's own chance of this, stated with the estimate: 55%); at least 1.2-fold (0.09 log units) between middle value and limit.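

In this assay compound 4 gives > 50000 nM as a limit and no number. Among these compounds, compound 2 also gives only a limit, so no step from compound 2 to compound 4 can be read. The compounds shown leave open whether 3,4-dichlorophenyl in place of 3-(trifluoromethyl)phenyl on an amide-type nitrogen changes inhibition of growth at all.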